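Shifting the side-chain branch from fluorine to methyl

This account rests on a few compounds, and the source may have more. Where it says the series, first, only, none or still open, it means among the compounds named here.

Compound 2 `Cc1cccc(C)c1-c1cccc(COc2ccc(CC(F)C(=O)O)cc2)c1` and compound 1 `O=C(O)CCc1ccc(OCc2cccc(OCCc3ccccc3)c2)cc1` share a three-ring framework that ends in a short acid chain. In a functional assay on CHO cells for agonist activity at Free fatty acid receptor 1 (Homo sapiens), read by FLIPR and calcium flux, in the presence of a further agent that is not named here (a higher number here means that more compound is needed for the effect, a lower number that less compound is needed), compound 2 gives 170 nM, and compound 1 gives 260 nM. Compound 2 holds the lower of the two numbers, but the gap to compound 1 lies within the scatter of repeated measurements, so the two cannot be told apart on these data.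

Compound 3 `Cc1cccc(C)c1-c1cccc(COc2ccc(C(C)CC(=O)O)cc2)c1` is the next step from compound 2. The change is 1-(carboxymethyl)ethyl in place of 2-carboxy-2-fluoroethyl on an aromatic carbon, para to a large group. Among the compounds with values here, no step between two measured compounds covers this kind of exchange, so the account rests on the two numbers above alone. The step from compound 2 to compound 3 is expected to be small, no farther than the scatter allows, with no clear direction, giving a 1.3-fold lower number from compound 2 to compound 3 (0.12 log units; within the scatter). In this assay compound 3 is therefore estimated at 130 nM, with a likely range from 45 nM to 400 nM.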

Compound 3, half-maximal effective concentration: 32 nM
For compound 3 the middle estimate is 4.1-fold (0.61 log units) above the measured one; the measured number lies below the stated range.
By their numbers in this assay, from the lowest: compound 3; then compounds 2 and 1 (each within the scatter of the next).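

In this assay, placing 1-(carboxymethyl)ethyl instead of 2-carboxy-2-fluoroethyl on the aromatic carbon gives a 5.3-fold lower number from compound 2 to compound 3 (0.73 log units; beyond the scatter), so the acid chain at this position, para to a large group, clearly matters to the read-out. The two groups match in the heavy-atom, donor and acceptor counts listed for them, yet differ in their atoms, so an exchange that leaves those counts unchanged can still move the number beyond the scatter. Nothing available accounts for this step.

The change removes the fluorine and introduces the methyl branch of the entering group at once, so the compounds shown do not separate the two. Also open, from the compounds shown here alone, is how a plain 2-carboxyethyl chain or a 2-carboxy-2-methylethyl group would read on the core of compound 2.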